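Fluorophenyl exchange on the fused core, stability notes

A few compounds are considered here, and "the series" means these few. Any claim that something is new, unique, unknown or untested is made for them only; others in the source may bear on it.

Compound 1 `C[C@H](Nc1ccnc(N)n1)c1cc2ccc(F)cn2c(=O)c1-c1ccccc1` has no result in an ADME assay on microsomes from liver (Rattus norvegicus), read by LC-MS, using NADPH, with a stated time of 30 min, tested at 1 uM; on this read-out lower numbers stand for a less stable compound and higher numbers for a more stable compound: there compound 1 gives "not determined" (no result reported). Going by the values given here, compound 2 `C[C@H](Nc1nc(N)nc(N)c1C#N)c1cc2ccc(F)cn2c(=O)c1-c1ccc(F)cc1` is the only member of the series with a number: in this assay compound 2 gives 87%. Compound 3 `C[C@H](Nc1nc(N)nc(N)c1C#N)c1cc(=O)n2cc(F)ccc2c1-c1ccc(F)cc1`, a close relative of compound 2 with the shared core in a different arrangement, has no single number either; in this assay compound 3 gives "not determined" (no result reported), so it stands on nothing measured of its own. The step to compound 4 `C[C@H](Nc1nc(N)nc(N)c1C#N)c1cc(=O)n2cc(F)ccc2c1-c1cc(F)cc(F)c1` is 3,5-difluorophenyl in place of 4-fluorophenyl on an aromatic carbon. Among the compounds with values here, no measured pair shows an exchange of this kind, so the size of the step in this assay is expected to be small, with no direction beyond the scatter. Compound 4 is expected to give 80%, within 55% to 96%, because its closest measured relative compound 2 gives 87%.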

Compound 4, percent of the compound remaining: 87%
For compound 4 the middle estimate is 7 percentage points below the measured one, within the range that was stated.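

Going by these compounds alone, compound 3 carries no single number, so no step to compound 4 can be read. The compounds shown leave open what 3,5-difluorophenyl in place of 4-fluorophenyl does in this assay. No evidence on this result is available.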